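The compounds below may be only part of what the source reports. "The series", "measured", "known", "first", "only" and "open" are said of these compounds alone.

Three dithiocarbamate-linked chalcones have been run in a functional assay on SK-N-SH cells (Homo sapiens) for inhibition, read by MTT assay, with a stated time of 72 h; on this read-out higher numbers stand for weaker inhibition and lower numbers for stronger inhibition. Compound 1 `CN1CCN(C(=S)SCCCOc2ccc(C(=O)/C=C/c3ccc(Cl)cc3)cc2)CC1` gives 31900 nM. Compound 2 `COc1cc(/C=C/C(=O)c2ccc(OCCSC(=S)N3CCCC3)cc2)cc(OC)c1OC` gives 12100 nM. Compound 3 `O=C(/C=C/c1ccc(Cl)cc1)c1ccc(OCCSC(=S)N2CCOCC2)cc1` gives 11700 nM, the lowest of the three numbers; its nearest neighbour is compound 2, whose value sits within the scatter of compound 3, so no order between those two can be read, while compound 1 sits beyond the scatter above compound 3.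

Compound 4 `O=C(/C=C/c1ccc(Cl)cc1)c1ccc(OCCSC(=S)N2CCCCC2)cc1` has not been measured in this assay. Against compound 3 the change is piperidin-1-yl in place of morpholin-4-yl on a thiocarbonyl carbon. Within the data shown here, the set holds no measured pair that differs only in this ring, so nothing here tells how the exchange moves the read-out. Without such a comparison the working expectation is a step of no more than the scatter, in either direction, which is what the estimated 1.2-fold lower number from compound 3 to compound 4 (0.07 log units; within the scatter) means. On that basis compound 4 is estimated at 10000 nM in this assay, with a range from 4000 nM to 25000 nM.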

Compound 4, half-maximal inhibitory concentration: 27400 nM
The estimate for compound 4 lay 2.7-fold (0.44 log units) below the measured number, and the stated range ends below it.
By their numbers in this assay, from the lowest: compounds 3 and 2 (each within the scatter of the next); then compounds 4 and 1 (each within the scatter of the next).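

In this assay, the ring on a thiocarbonyl carbon now has its first one-place comparison: piperidin-1-yl in place of morpholin-4-yl gives a 2.3-fold higher number from compound 3 to compound 4 (0.37 log units; beyond the scatter). The ring is therefore not a freely interchangeable part of this series, since exchanging the oxygen of morpholin-4-yl for carbon is enough to weaken inhibition on the core of compound 3, although this single pair sets no rule for other cores. Nothing available bears on the reason for this step.

On these data alone, whether thiomorpholin-4-yl or an open-chain diethylamino group on a thiocarbonyl carbon would read closer to compound 3 or to compound 4 remains open. Also open, as far as these compounds go, is whether the same exchange gives a similar step on the core of compound 2.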